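Swapping an allyl chain for 2-acetylethyl

The source may report more compounds than this note shows. Statements on the series, on what has been measured and on what is new or still open speak of the compounds shown alone.

For the measured compounds named here, in an ADME assay on TZM cells (Homo sapiens) for cytotoxicity, read by XTT assay, with a stated time of 4 days (on this read-out lower numbers stand for higher toxicity in this test and higher numbers for lower toxicity in this test), compound 3 (`C=CCc1cc(C)c(Oc2ccc(N)c(Nc3ccc(C#N)cc3)n2)c(C)c1`) gives 8460 nM as the only true number among the measured compounds. Compound 1 (`CC(=O)/C=C/c1cc(C)c(Oc2ccc([N+](=O)[O-])c(Nc3ccc(C#N)cc3)n2)c(C)c1`) reads > 46700 nM as a limit of the assay. Compound 2 (`Cc1cc(/C=C/C#N)cc(C)c1Oc1ccc([N+](=O)[O-])c(Nc2ccc(C#N)cc2)n1`) reads > 48600 nM as a limit too. Going by the values given here, the only measured step is a step that the two limits leave unreadable from compound 1 to compound 2 and it concerns a different change, so it offers no size to borrow. Compound 4 (`CC(=O)CCc1cc(C)c(Oc2ccc(N)c(Nc3ccc(C#N)cc3)n2)c(C)c1`) differs from compound 3 as follows: 2-oxopropyl in place of vinyl on a saturated chain carbon bound to an aromatic carbon and so allyl gives way to 2-acetylethyl. Nothing measured bears on this change, so no step beyond the usual scatter is expected in this assay. The expected step is a 1.3-fold higher number from compound 3 to compound 4 (0.11 log units; within the scatter) and its direction is uncertain. For compound 4 the estimated half-maximal cytotoxic concentration is 11000 nM within an expected range of 4000 nM to 35000 nM on this read-out.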

Compound 4, half-maximal cytotoxic concentration: 9250 nM
Estimate against measurement, compound 4: 1.2-fold (0.08 log units) above; the measured number falls inside the stated range.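

In this assay, swapping allyl for 2-acetylethyl gives a 1.1-fold higher number from compound 3 to compound 4 (0.04 log units; within the scatter). This is the first readable step among the compounds shown. It shows that this place, on a saturated chain carbon bound to an aromatic carbon, can carry a longer chain with a carbonyl while the number stays within the scatter. No measurement shown explains this result. Still open, from the compounds shown here alone, is whether a carboxylic acid or an amine at the end of this chain would also stay within the scatter, and whether a longer chain would.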